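A few compounds are considered here, and "the series" means these few. Any claim that something is new, unique, unknown or untested is made for them only; others in the source may bear on it.

In a functional assay on MGC-803 cells (Homo sapiens) for cytotoxicity, read by MTT assay, with a stated time of 72 h (a higher number here means a weaker inhibitor, a lower number a stronger inhibitor), compound 3 `COc1ccc(C=C2C(=O)N(c3ccc(Cl)cc3)N(c3ccc(Cl)cc3)C2=O)cc1` gives only a limit, > 128000 nM, and no number. Compound 1 `O=C1C(=Cc2ccc(F)cc2)C(=O)N(c2ccc(Cl)cc2)N1c1ccc(Cl)cc1` gives 26000 nM and compound 2 `O=C1C(=Cc2ccc(Cl)cc2)C(=O)N(c2ccc(Cl)cc2)N1c1ccc(Cl)cc1` gives 32600 nM, and chloro in place of fluoro there gave a 1.3-fold higher number from compound 1 to compound 2 (0.10 log units; within the scatter). Compound 4 `O=C1C(=Cc2cccc(Cl)c2)C(=O)N(c2ccc(Cl)cc2)N1c1ccc(Cl)cc1` differs from compound 3 by 3-chlorophenyl in place of 4-methoxyphenyl on a double-bonded chain carbon bound to a double-bonded ring carbon, with 3-chlorophenyl in place of 4-methoxyphenyl. Going by the values given here, two measured steps bear on this: methoxy in place of chloro gave an at least 3.9-fold higher number from compound 2 to compound 3 (0.59 log units; beyond the scatter), and methoxy in place of fluoro gave an at least 4.9-fold higher number from compound 1 to compound 3 (0.69 log units; beyond the scatter). Among the compounds with values here, no measured compound carries 3-chlorophenyl, so this is an inference. Leaving methoxy should reverse those steps, and the expected change is an at least 3.6-fold lower number from compound 3 to compound 4 (0.56 log units; beyond the scatter), a lower number beyond the scatter. For compound 4 the estimated value is 35000 nM, with an expected range of 15000 nM to 85000 nM.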

Compound 4, half-maximal inhibitory concentration: 14400 nM
For compound 4 the middle estimate is 2.4-fold (0.39 log units) above the measured one; the measured number lies below the stated range.
By their numbers in this assay, from the lowest: compounds 4, 1 and 2 (each within the scatter of the next, the first and the last beyond it). At a limit, above all of these: compound 3.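

In this assay, going by these compounds alone, 3-chlorophenyl in place of 4-chlorophenyl gave a 2.3-fold lower number from compound 2 to compound 4 (0.35 log units; beyond the scatter), so the place of the chlorine on this ring can change the result, which the earlier compounds could not show. Against 4-fluorophenyl, the same group gave a 1.8-fold lower number from compound 1 to compound 4 (0.26 log units; within the scatter), which leaves that pair unseparated. Against 4-methoxyphenyl, it gave an at least 8.8-fold lower number from compound 3 to compound 4 (0.94 log units; beyond the scatter), a step that is only a bound, as its starting value is a limit: the limit of > 128000 nM in this assay, at which 1 of the 4 values shown sits.

Still open, as far as these compounds go, is whether the lower number depends on chlorine itself or would hold for other groups in that place. A 3-fluorophenyl, a 3-methoxyphenyl or a 3-aminophenyl group would test this.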